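Thiophene for furan on the saturated ring carbon

A few compounds are considered here, and "the series" means these few. Any claim that something is new, unique, unknown or untested is made for them only; others in the source may bear on it.

Compound 3 `CC1=C(C(=O)SC(C)C)C(c2ccoc2)NC(=O)N1` is assessed in an assay on membranes from HeLa cells for displacement of a labelled ligand from adenosine receptor A3 (Homo sapiens), read by scintillation counting, with a stated time of 180 min, tested at 1 uM (on this read-out higher numbers stand for more inhibition at the one concentration tested (going by the name of the read-out) and lower numbers for less inhibition), and gives 3%. Compound 1 `CC1=C(C(=O)OC(C)(C)C)C(c2ccsc2)NC(=O)N1` gives 1% and compound 2 `CC1=C(C(=O)C2CC2)C(c2ccsc2)NC(=O)N1` gives 1% in this assay; the gaps from compound 3 to each of them lie within the scatter, so the three sit together. Going by the values given here, the one measured step, no change at the digits printed from compound 1 to compound 2 (within the scatter), concerns the carbonyl carbon and does not touch the ring in question. Compound 4 `CC1=C(C(=O)SC(C)C)C(c2ccsc2)NC(=O)N1` differs from compound 3 by thiophen-3-yl in place of furan-3-yl on a saturated ring carbon. Among the compounds with values here, no measured step covers this change; compounds 1 and 2 carry the entering group and sit with compound 3. Compound 4 is therefore expected to show a number 1 percentage points lower from compound 3 to compound 4 (within the scatter). Compound 4 is estimated at 2%, between -5% and 10%.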

Compound 4, a percentage reported as inhibition, at one concentration (the size of the read-out at that concentration, not a potency): 1%
Beside the measured number, compound 4's estimate is 1 percentage points above it; the range from low to high includes it.
By their numbers in this assay, from the lowest: compounds 1, 2, 4 and 3 (each within the scatter of the next).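

With thiophen-3-yl in place of furan-3-yl on the saturated ring carbon, this position now has a measured step in this assay (a number 2 percentage points lower from compound 3 to compound 4 (within the scatter)), so the exchange leaves the read-out within the scatter. With thiophen-3-yl held constant, isopropylsulfanyl in place of cyclopropyl gives (no change at the digits printed from compound 2 to compound 4 (within the scatter)), and isopropylsulfanyl in place of tert-butoxy gives (no change at the digits printed from compound 1 to compound 4 (within the scatter)), so these carbonyl-carbon groups also stay within the scatter. No evidence is available to explain these results.

On these data alone, because all four numbers lie close together, it remains open whether this ring exchange would matter in a compound with a clearly higher number. As far as these compounds go, the effect of an amine on the thiophen-3-yl ring, or of a longer chain on the carbonyl carbon, also remains open.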